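The source may report more compounds than this note shows. Statements on the series, on what has been measured and on what is new or still open speak of the compounds shown alone.

In a functional assay on A549 cells (Homo sapiens) for cytotoxicity, read by MTT assay, with a stated time of 72 h (a higher number here means a weaker inhibitor, a lower number a stronger inhibitor), compound 1 (`O=C(/C=C/c1cccc(Cl)c1Cl)Nc1cc2c(Nc3ccc(F)c(Cl)c3)ncnc2cc1O[C@H]1CCOC1`) gives 23200 nM and compound 2 (`COc1cc(/C=C/C(=O)Nc2cc3c(Nc4ccc(F)c(Cl)c4)ncnc3cc2O[C@H]2CCOC2)cc(OC)c1OC`) gives 4150 nM, the lower of the two numbers available. Compound 3 (`N#Cc1ccc(/C=C/C(=O)Nc2cc3c(Nc4ccc(F)c(Cl)c4)ncnc3cc2O[C@H]2CCOC2)cc1`) is reported only as "not active" (no number reported). Compound 4 (`COc1cc2ncnc(Nc3ccc(F)c(Cl)c3)c2cc1NC(=O)/C=C/c1cc(OC)c(OC)c(OC)c1`) differs from compound 2 by methyl in place of oxolan-3-yl on an oxygen on an aromatic ring. Within the data shown here, the only measured step, a 5.6-fold lower number from compound 1 to compound 2 (0.75 log units; beyond the scatter), concerns the aryl group on a double-bonded chain carbon, not this oxygen, so no measured step speaks directly to the change. Without such evidence, no shift beyond the scatter is expected, and the estimated step is a 1.1-fold higher number from compound 2 to compound 4 (0.04 log units; within the scatter). For compound 4, the expected value is 4500 nM, with an estimated range of 1500 nM to 14000 nM.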

Compound 4, half-maximal inhibitory concentration: "not active" (no number reported)
No number was reported for compound 4; the estimate stays without a comparison.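

Compound 4 is reported only as "not active" in this assay, so no new step can be read from compound 2 to compound 4. The compounds shown leave open how far methyl in place of oxolan-3-yl moves the number. No supporting evidence bears on this result.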